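This account rests on a few compounds, and the source may have more. Where it says the series, first, only, none or still open, it means among the compounds named here.

Three compounds of the series have so far been run in an ADME assay on BJ cells (Homo sapiens) for cytotoxicity, read by luminescence, with a stated time of 72 h; on this read-out higher numbers stand for an effect only at larger amounts of compound and lower numbers for an effect already at smaller amounts. Compound 1 `CCOC(=O)c1c(-c2cccc(-c3ccccc3)c2)[nH]c2cc(OC)ccc2c1=O` carries a phenyl on the aromatic carbon of the pendant ring, compound 2 `CCOC(=O)c1c(-c2cccc(OCC(C)C)c2)[nH]c2cc(OC)ccc2c1=O` an isobutoxy at that place, and compound 3 `CCOC(=O)c1c(-c2cccc(OC(F)(F)F)c2)[nH]c2cc(OC)ccc2c1=O` a trifluoromethoxy. In this assay compound 1 gives only a limit, > 21500 nM. In this assay compound 2 likewise gives only a limit, > 21500 nM. In this assay compound 3 also gives only a limit, > 21500 nM. With every value sitting at the limit of > 21500 nM in this assay, at which 3 of the 3 values shown sit, the steps a step that the two limits leave unreadable from compound 1 to compound 2, a step that the two limits leave unreadable from compound 1 to compound 3 and a step that the two limits leave unreadable from compound 2 to compound 3 cannot be read as numbers; compound 2 stands at the same limit as the other two, with no ordering among them.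

Compound 4 `CCOC(=O)c1c(-c2cccc(O)c2)[nH]c2cc(OC)ccc2c1=O` is the next member, differing from compound 2 by hydrogen in place of isobutyl on an oxygen on an aromatic ring. For the measured compounds named here, none of the measured steps gives a readable size for a change at this oxygen; all three steps around compound 2 are unreadable, each value being a limit. The earlier exchanges of phenyl, isobutoxy and trifluoromethoxy all left the read-out at its limit. In this assay compound 4 is therefore expected to remain at the limit as well, the expected step being a step that the limit leaves unreadable from compound 2 to compound 4, nothing beyond scatter. The estimate for compound 4 in this assay is 30000 nM, with a range from 15000 nM to 70000 nM, and most likely only a limit is again reported.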

Compound 4, half-maximal effective concentration: > 21500 nM
Compound 4 gave a limit, no number; the forecaster's own chance of this, stated with the estimate: 85%; the middle value is on the limit's open side.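

No new step can be read in this assay: the steps between compound 4 and compounds 1, 2 and 3 each join two limits and have no readable size. Compounds 1, 2, 3 and 4 all share one reading: the limit of > 21500 nM in this assay, at which 4 of the 4 values shown sit.

What the compounds shown leave open is whether any group at this place moves the read-out in this assay, as none of them gives a number.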